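Moving a methyl group around a benzyl ring

This account rests on a few compounds, and the source may have more. Where it says the series, first, only, none or still open, it means among the compounds named here.

Measured compounds:
Compound 1, `Cc1cc(S(=O)(=O)/N=C(\N)n2nccc2-c2ccccc2)c(SCc2ccc(Cl)cc2)cc1Cl`: 7000 nM
Compound 2, `Cc1cc(-c2ccccc2)n(/C(N)=N/S(=O)(=O)c2cc(C)c(Cl)cc2SCc2ccccc2C)n1`: 42000 nM
Compound 3, `Cc1cc(S(=O)(=O)/N=C(\N)n2nccc2-c2ccccc2)c(SCc2cccc(C(F)(F)F)c2)cc1Cl`: 14000 nM

All three were tested in a functional assay on HCT-116 cells (Homo sapiens) for cytotoxicity, read by MTT assay, with a stated time of 72 h; a higher number here means a weaker inhibitor, a lower number a stronger inhibitor. Compound 2 gives the highest of the three numbers, so it is the weakest of the set; compound 3 and compound 1 both give clearly lower numbers, beyond the usual scatter.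

The step under consideration leads to compound 4, `Cc1ccc(CSc2cc(Cl)c(C)cc2S(=O)(=O)/N=C(\N)n2nc(C)cc2-c2ccccc2)cc1`, which is not yet measured. Compound 4 differs from compound 2 only in how the same atoms are joined: 4-methylphenyl in place of 2-methylphenyl on a saturated chain carbon bound to a sulfur.

Within the data shown here, only one measured step touches this part of the molecule, the change on a saturated chain carbon bound to a sulfur from compound 1 to compound 3: a 2.0-fold higher number from compound 1 to compound 3 (0.30 log units; within the scatter). That step did not move the number beyond the scatter, so swapping one aryl group for another at this place has so far shown little effect. The data give no direct comparison of 2-methylphenyl against 4-methylphenyl.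

For compound 4 a modest drop toward the other two compounds is expected, a 2.1-fold lower number from compound 2 to compound 4 (0.32 log units; beyond the scatter), because compound 1, which also carries a group at the corresponding place on the benzyl ring, gives 7000 nM. Compound 4 is therefore estimated at 20000 nM, with a range from 7000 nM to 60000 nM.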

Compound 4, half-maximal inhibitory concentration: 28000 nM
Compound 4: the middle estimate sits 1.4-fold (0.15 log units) below what was measured; the range from low to high includes it.
By their numbers in this assay, from the lowest: compounds 1, 3, 4 and 2 (each within the scatter of the next, the first and the last beyond it).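

In this assay, moving the methyl group from 2-methylphenyl to 4-methylphenyl on a saturated chain carbon bound to a sulfur gives a 1.5-fold lower number from compound 2 to compound 4 (0.18 log units; within the scatter). Among these compounds, this is the first direct test of where the methyl sits on this ring, and the two placements cannot be told apart in this assay. With the earlier swap of two different aryl groups, a 2.0-fold higher number from compound 1 to compound 3 (0.30 log units; within the scatter), both steps measured at this place now stay within the scatter, and neither goes against that reading. No measurement shown here accounts for this result.

As far as these compounds go, it remains open whether any change at this place can move the number beyond the scatter. An amine or a carboxylic acid on the ring, or a longer chain in place of the saturated chain carbon, does not appear among the compounds shown.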